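Amide aryl variation on the shared core: toward compound 4

The source may report more compounds than this note shows. Statements on the series, on what has been measured and on what is new or still open speak of the compounds shown alone.

Measured so far in a functional assay on WI-38 VA13 cells (Homo sapiens) for cytotoxicity; on this read-out higher numbers stand for an effect only at larger amounts of compound and lower numbers for an effect already at smaller amounts:
compound 1 `Cc1ccccc1C(=O)Nc1ccc2nc(NC(=O)C3CCCCC3)sc2c1`: 0.085 ug/mL
compound 2 `O=C(Nc1ccc2nc(NC(=O)C3CCCCC3)sc2c1)c1ccccc1C(F)(F)F`: 0.024 ug/mL
compound 3 `O=C(Nc1ccc2nc(NC(=O)C3CCCCC3)sc2c1)c1ccc(Br)cc1`: > 4 ug/mL

Compounds 1, 2 and 3 share one core and differ only in the aryl on the carbonyl carbon. Between compound 1 and compound 2 the change is a 3.5-fold lower number from compound 1 to compound 2 (0.55 log units; beyond the scatter). From the compounds shown here alone, for compound 3 this assay returns only a limit, > 4 ug/mL; compound 3 thus sits at the limit of > 4 ug/mL in this assay, at which 1 of the 3 values shown sits, and its exact position is unknown. Both an at least 47-fold higher number from compound 1 to compound 3 (1.67 log units; beyond the scatter) and an at least 160-fold higher number from compound 2 to compound 3 (2.22 log units; beyond the scatter) were large.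

Compound 4 `O=C(Nc1ccc2nc(NC(=O)C3CCCCC3)sc2c1)c1ccc(Cl)cc1Cl` is not yet measured. It differs from compound 3 by 2,4-dichlorophenyl in place of 4-bromophenyl on a carbonyl carbon. Among the measured compounds shown here, compounds 1 and 2 carry 2-methylphenyl or 2-(trifluoromethyl)phenyl, compound 4 carries 2,4-dichlorophenyl; no measured step isolates exactly this change, so the expectation is loose. Compound 4 is expected to give 1 ug/mL, with a range from 0.1 ug/mL to 8 ug/mL. The expected step is an at least 4.0-fold lower number from compound 3 to compound 4 (0.60 log units; beyond the scatter).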

Compound 4, half-maximal effective concentration: > 4 ug/mL
Compound 4: no number, only a limit; the forecaster's own chance of this, stated with the estimate: 30%; middle value at least 4.0-fold (0.60 log units) away from the limit.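

In this assay compound 4 returns only a limit, as compound 3 does, and the step between these two cannot be read: the limit of > 4 ug/mL in this assay, at which 2 of the 4 values shown sit. The change to 2,4-dichlorophenyl on the carbonyl carbon gives an at least 47-fold higher number from compound 1 to compound 4 (1.67 log units; beyond the scatter) and an at least 160-fold higher number from compound 2 to compound 4 (2.22 log units; beyond the scatter). Among the four compounds, the two halogen-only aryl groups, 4-bromophenyl and 2,4-dichlorophenyl, both end at the limit, whereas 2-methylphenyl and 2-(trifluoromethyl)phenyl give numbers.

From the compounds shown here alone, how far compound 3 and compound 4 lie past that limit stays open. Also open, going by these compounds, is whether a phenyl carrying a single chlorine, or an amine, would return a number.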